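Dichlorophenyl in Place of Difluorophenyl on the Shared Core

This account rests on a few compounds, and the source may have more. Where it says the series, first, only, none or still open, it means among the compounds named here.

Of the compounds shown here, three built on one core have been tested in a functional assay on HepG2 cells (Homo sapiens) for inhibition, read by MTT assay, with a stated time of 72 h; on this read-out lower numbers stand for stronger inhibition and higher numbers for weaker inhibition. Compound 1 `CN(C(=O)NC(=O)c1ccc(Cl)cc1Cl)c1nc(C(F)(F)F)c(C(=O)N/N=C/c2cccc(C(F)(F)F)c2)s1` gives 11.2 ug/mL. Compound 2 `CN(C(=O)NC(=O)c1ccccc1F)c1nc(C(F)(F)F)c(C(=O)N/N=C/c2cc(C(F)(F)F)cc(C(F)(F)F)c2)s1` gives 4.47 ug/mL. Compound 3 `CN(C(=O)NC(=O)c1ccc(F)c(F)c1)c1nc(C(F)(F)F)c(C(=O)N/N=C/c2cc(C(F)(F)F)cc(C(F)(F)F)c2)s1` gives 5.47 ug/mL, which is the second highest of the three numbers; compound 2 lies nearest to it, and compound 1 furthest, beyond the scatter. Compound 4 `CN(C(=O)NC(=O)c1ccc(Cl)cc1Cl)c1nc(C(F)(F)F)c(C(=O)N/N=C/c2cc(C(F)(F)F)cc(C(F)(F)F)c2)s1` has not yet been measured. The change is 2,4-dichlorophenyl in place of 3,4-difluorophenyl on a carbonyl carbon. Among the measured compounds shown here, only one measured step alters the same group on the carbonyl carbon: a 1.2-fold higher number from compound 2 to compound 3 (0.09 log units; within the scatter), which lay within the scatter. For the measured compounds named here, compound 1 carries the same 2,4-dichlorophenyl group as compound 4 but differs from compound 3 in a second place as well, so it gives no clean step. The expectation for this assay is therefore a small rise at most, a 1.3-fold higher number from compound 3 to compound 4 (0.11 log units; within the scatter), leaning towards the higher number because compound 1 gives 11.2 ug/mL. Compound 4 is estimated at 7 ug/mL, with a range from 3.5 ug/mL to 14 ug/mL.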

Compound 4, half-maximal inhibitory concentration: > 100 ug/mL
Compound 4: no number, only a limit; the forecaster's own chance of this, stated with the estimate: 5%; middle value at least 14-fold (1.15 log units) from the limit.
By their numbers in this assay, from the lowest: compounds 2 and 3 (each within the scatter of the next); then compound 1. At a limit, above all of these: compound 4.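

In this assay compound 4 gives > 100 ug/mL, which is a limit of the assay and not a number: the limit of > 100 ug/mL in this assay, at which 1 of the 4 values shown sits.

The fluorinated compounds 2 and 3 gave no sign that the group on this carbonyl carbon matters much, yet 2,4-dichlorophenyl brings an at least 18-fold higher number from compound 3 to compound 4 (1.26 log units; beyond the scatter) and an at least 22-fold higher number from compound 2 to compound 4 (1.34 log units; beyond the scatter). With 2,4-dichlorophenyl kept in place, the other end of the molecule matters too: trifluoromethyl in place of hydrogen on an aromatic carbon brings an at least 8.9-fold higher number from compound 1 to compound 4 (0.95 log units; beyond the scatter), so the outcome of the chlorine change may depend on what else the molecule carries.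

The true size of these steps stays unknown, and no cause for them can be read from these compounds. Nothing shown carries a plain phenyl or a methoxyphenyl group on this carbonyl carbon, so it remains open how far other groups here would be tolerated.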